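Notes on a repeated cyclopropyl-to-propyl change at the carbonyl

The source may report more compounds than this note shows. Statements on the series, on what has been measured and on what is new or still open speak of the compounds shown alone.

Compound 1 `CC1=C(C(=O)C2CC2)C(c2ccco2)NC(=O)N1`, compound 2 `CCCC(=O)C1=C(C)NC(=O)NC1c1ccco1` and compound 3 `CC1=C(C(=O)C2CC2)C(c2ccoc2)NC(=O)N1` have been run in an assay on membranes from CHO cells for displacement of a labelled ligand from adenosine receptor A1 (Homo sapiens), read by scintillation counting, with a stated time of 60 min, tested at 1 uM; a higher number here means more inhibition at the concentration tested (going by the name of the read-out), a lower number less inhibition; compound 4 `CCCC(=O)C1=C(C)NC(=O)NC1c1ccoc1` has not. In this assay compound 1 gives 2%. In this assay compound 2 gives 1%, and compound 3 gives 1%. All three numbers sit at the floor of the read-out.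

The difference between compound 1 and compound 2 is propyl in place of cyclopropyl on a carbonyl carbon; this gave a number 1 percentage points lower from compound 1 to compound 2 (within the scatter). The two cores differ by furan-3-yl in place of furan-2-yl on a saturated ring carbon, a step that gave a number 1 percentage points lower from compound 1 to compound 3 (within the scatter). Compound 3 and compound 2 show the same number at the digits reported.

Compound 4 differs from compound 3 by propyl in place of cyclopropyl on a carbonyl carbon, the same change as that from compound 1 to compound 2, made at the same place described on the core of compound 3. For the measured compounds named here, the one earlier instance of this change moved nothing beyond the scatter, and the values of compound 1, compound 2 and compound 3 all lie at the floor of the read-out; a flat step is therefore expected for no change at the digits printed from compound 3 to compound 4 (within the scatter). The expectation for compound 4 in this assay is 1%, with a range from -6% to 9%. This rests on compound 3 at 1% and on the earlier step of a number 1 percentage points lower from compound 1 to compound 2 (within the scatter), which stayed within the scatter.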

Compound 4, a percentage reported as inhibition, at one concentration (the size of the read-out at that concentration, not a potency): 1%
Compound 4: the middle estimate sits on the measured number at the digits printed; measured number inside the range.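

Propyl in place of cyclopropyl on a carbonyl carbon gives no change at the digits printed from compound 3 to compound 4 (within the scatter) in this assay, and set beside its earlier instance the change reads the same on both cores: the same change on two cores in this assay, a number 1 percentage points lower (within the scatter) from compound 1 to compound 2 and no change at the digits printed (within the scatter) from compound 3 to compound 4, 1 percentage points apart, within the scatter of two such steps.

Furan-3-yl in place of furan-2-yl on a saturated ring carbon gives no change at the digits printed from compound 2 to compound 4 (within the scatter), and this change also reads the same on both cores: the same change on two cores in this assay, a number 1 percentage points lower (within the scatter) from compound 1 to compound 3 and no change at the digits printed (within the scatter) from compound 2 to compound 4, 1 percentage points apart, within the scatter of two such steps.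

For the compounds shown here, all four compounds lie at the floor of the read-out, so this shows only that neither change brings a number clear of the floor on these cores; it does not show that either change would be silent on a core with measurable inhibition, and a flat step at the floor says nothing on whether a step of real size would carry over.

The compounds shown leave open whether any group on the shared core can bring the read-out off the floor, for instance a longer chain such as pentyl on the carbonyl carbon, or an amine-bearing group in place of the furan ring. They also leave open how these four compounds would read at a higher concentration, where differences now hidden at the floor might appear.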